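Removing the tert-butyl group from compound 2

The source may hold more compounds than are shown below. What is called first, only, known or untested is meant among the compounds shown, and "the series" means these compounds.

Values so far in a functional assay on NCI-H460 cells (Homo sapiens) for cytotoxicity, read by MTT assay, with a stated time of 72 h; a higher number here means a weaker inhibitor, a lower number a stronger inhibitor:
- compound 1 `CC(C)(C)c1[nH]cnc1/C=c1\[nH]c(=O)/c(=C/c2cccc(C(=O)c3ccc(F)cc3)c2)[nH]c1=O` gives 3.8 nM
- compound 2 `CC(C)(C)c1[nH]cnc1/C=c1\[nH]c(=O)/c(=C/c2cccc(Oc3ccc(F)cc3)c2)[nH]c1=O` gives 4 nM
- compound 3 `Cc1[nH]cnc1/C=c1\[nH]c(=O)/c(=C/c2cccc(C(=O)c3ccc(F)cc3)c2)[nH]c1=O` gives 15.9 nM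

Compound 2 belongs with compound 1 at the low end of these three numbers (a 1.1-fold higher number from compound 1 to compound 2 (0.02 log units; within the scatter)), and the number of compound 3 lies higher. Compound 4 `O=c1[nH]/c(=C\c2c[nH]cn2)c(=O)[nH]/c1=C\c1cccc(Oc2ccc(F)cc2)c1` carries hydrogen in place of tert-butyl on an aromatic carbon. The nearest measured precedent is methyl in place of tert-butyl (a 4.2-fold higher number from compound 1 to compound 3 (0.62 log units; beyond the scatter)), a modest step. Within the data shown here, no measured compound yet has hydrogen at this place, so the size of the step is uncertain. A step in the same direction and somewhat larger seems likely, and the expected step is a 13-fold higher number from compound 2 to compound 4 (1.10 log units; beyond the scatter) in this assay as an estimate. For compound 4 an estimated 50 nM (range 15 nM to 250 nM) is expected.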

Compound 4, half-maximal inhibitory concentration: 479 nM
Compound 4: middle estimate off by 9.6-fold (0.98 log units), on the low side; measured number above the stated range.
By their numbers in this assay, from the lowest: compounds 1 and 2 (each within the scatter of the next); then compound 3; then compound 4.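

In this assay, this position tolerates no simple loss of its substituent: replacing tert-butyl with hydrogen gives a 120-fold higher number from compound 2 to compound 4 (2.08 log units; beyond the scatter), a large step. This exceeds the modest methyl step, a 4.2-fold higher number from compound 1 to compound 3 (0.62 log units; beyond the scatter), although that step belongs to the (4-fluorophenyl)carbonyl pair, so the two steps do not share a background. No available evidence accounts for the size of the hydrogen step.

Still open, going by these compounds, is how ethyl or isopropyl at this place would compare with tert-butyl. Also open, on these data alone, is whether the hydrogen step would be similar with the (4-fluorophenyl)carbonyl group.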